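This account rests on a few compounds, and the source may have more. Where it says the series, first, only, none or still open, it means among the compounds named here.

Compound 3 `C=C1C[C@]23C[C@@]1(O)CC[C@H]2c1ccc(OS(=O)(=O)c2ccc(C)cc2)c(C)c1[C@@H]3Cn1cc(-c2ccc(C)cc2)nn1` sits, in a functional assay on HL-60 cells (Homo sapiens) for cytotoxicity, read by MTT assay, with a stated time of 4 days (on this read-out higher numbers stand for weaker inhibition and lower numbers for stronger inhibition), only at a limit and gives > 20000 nM. Compound 1 `C=C1C[C@]23C[C@@]1(O)CC[C@H]2c1ccc(OS(=O)(=O)c2ccc(C)cc2)c(C)c1[C@@H]3Cn1cc(-c2ccc(Br)cc2)nn1` also gives only a limit, > 20000 nM. Among the compounds with values here, compound 2 `C=C1C[C@]23C[C@@]1(O)CC[C@H]2c1ccc(O)c(C)c1[C@@H]3Cn1cc(-c2ccc(C(F)(F)F)cc2)nn1` gives 8950 nM; no step between compound 2 and compound 3 is counted, so the two values stand side by side without a size. The change to compound 4 `C=C1C[C@]23C[C@@]1(O)CC[C@H]2c1ccc(OS(=O)(=O)c2ccc(C)cc2)c(C)c1[C@@H]3Cn1cc(-c2ccc(C(F)(F)F)cc2)nn1` is trifluoromethyl in place of methyl on an aromatic carbon. Within the data shown here, the one measured step at the same position, a step that the two limits leave unreadable from compound 1 to compound 3, has no readable size because both ends sit at the limit of > 20000 nM in this assay, at which 2 of the 3 values shown sit. Among the measured compounds shown here, no measured step therefore sets a size for the step from compound 3 to compound 4. The expected step that the limit leaves unreadable from compound 3 to compound 4 is none beyond the scatter. Compound 4 is estimated at 25000 nM, within 9000 nM to 70000 nM, most likely again a limit.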

Compound 4, half-maximal inhibitory concentration: > 20000 nM
Compound 4: a limit, no number; the forecaster's own chance of this, stated with the estimate: 70%; the middle value lies beyond the limit too.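

With trifluoromethyl held constant, this assay gives the series its first readable size: (4-methylphenyl)sulfonyl in place of hydrogen on the oxygen on an aromatic ring gives an at least 2.2-fold higher number from compound 2 to compound 4 (0.34 log units; beyond the scatter). This size is a bound only, since one end of the step is a limit. The steps among compound 1, compound 3 and compound 4 cannot be read, so bromo, methyl and trifluoromethyl cannot be ranked with the sulfonyl group present: the limit of > 20000 nM in this assay, at which 3 of the 4 values shown sit.

From the compounds shown here alone, how methyl or bromo reads with hydrogen on that oxygen stays open. So does whether an amine or a carboxylic acid in place of trifluoromethyl on the aromatic carbon would give a number rather than a limit.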